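Three compounds at the assay limit, a fourth pending

The compounds below may be only part of what the source reports. "The series", "measured", "known", "first", "only" and "open" are said of these compounds alone.

compound 1, `O=C(O)C1=Cc2ccccc2OC1(OCc1cc(-c2ccc([N+](=O)[O-])cc2)no1)C(F)(F)F`: in a functional assay on A549 cells (Homo sapiens) for inhibition, read by MTT assay, with a stated time of 24 h (on this read-out higher numbers stand for weaker inhibition and lower numbers for stronger inhibition), compound 1 gives only the limit > 150000 nM.
compound 2, `O=C(O)C1=Cc2ccccc2OC1(OCc1cc(-c2ccc(F)cc2)no1)C(F)(F)F`: in this assay compound 2 gives only the limit > 150000 nM.
compound 3, `O=C(O)C1=Cc2ccccc2OC1(OCc1cc(-c2cccc(C(F)(F)F)c2)no1)C(F)(F)F`: in this assay compound 3 gives only the limit > 150000 nM.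

Compound 3 stands nowhere in particular on these numbers: its value is a limit, and the two companions shown beside it are limits as well, all three sitting at the limit of > 150000 nM in this assay, at which 3 of the 3 values shown sit. The steps a step that the two limits leave unreadable from compound 1 to compound 2, a step that the two limits leave unreadable from compound 1 to compound 3 and a step that the two limits leave unreadable from compound 2 to compound 3 are accordingly unreadable in size and direction; nothing in them says whether exchanging one aryl group for another moves the read-out at all.

The next compound, compound 4, `COc1ccc(-c2cc(COC3(C(F)(F)F)Oc4ccccc4C=C3C(=O)O)on2)cc1`, differs from compound 3 by 4-methoxyphenyl in place of 3-(trifluoromethyl)phenyl on an aromatic carbon. Within the data shown here, none of the measured steps bears on this change beyond the bare fact that the three aryl variants already tried all ended at the limit of > 150000 nM in this assay, at which 3 of the 3 values shown sit. The expectation for compound 4 is therefore no readable step, with a step that the limit leaves unreadable from compound 3 to compound 4 as the expected change and a further limit as the most likely outcome. Compound 4 is estimated at 200000 nM, with a range from 100000 nM to 600000 nM in this assay.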

Compound 4, half-maximal inhibitory concentration: 36200 nM
Beside the measured number, compound 4's estimate is 5.5-fold (0.74 log units) above it, outside the stated range (below it).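

The aromatic carbon next to the ring nitrogen of the five-membered ring is now shown to be a place where the aryl group can move the read-out in this assay: 4-methoxyphenyl in place of 3-(trifluoromethyl)phenyl gives an at least 4.1-fold lower number from compound 3 to compound 4 (0.61 log units; beyond the scatter). The same holds for the two changes on the para-free comparison of the phenyl substituent, with methoxy in place of fluoro giving an at least 4.1-fold lower number from compound 2 to compound 4 (0.61 log units; beyond the scatter) and methoxy in place of nitro giving an at least 4.1-fold lower number from compound 1 to compound 4 (0.61 log units; beyond the scatter), and each of these sizes is only a bound, since each step starts from a limit. Compounds 1, 2 and 3 remain together at a limit, and the steps among them still cannot be read: the limit of > 150000 nM in this assay, at which 3 of the 4 values shown sit.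

With compound 4 as the only aryl variant giving a number, the compounds shown cannot tell whether the gain belongs to methoxy itself or to any group other than the three that stay at the limit. An ethoxy group, a dimethylamino group or a hydroxyl group on the same phenyl carbon would show whether the step extends beyond compound 4, and the same question stands for the carboxylic acid of the shared core, should an amide take its place.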